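A few compounds are considered here, and "the series" means these few. Any claim that something is new, unique, unknown or untested is made for them only; others in the source may bear on it.

Among the three measured compounds, compound 3, `O=C(NO)c1ccc(/C=C/c2ccnc(-c3cc(F)ccc3O)c2)cc1`, gives the lowest number: in an assay on isolated protein for inhibition of protein deacetylase HDAC6 (Homo sapiens), read by fluorescence, with a stated time of 15 min (on this read-out lower numbers stand for stronger inhibition and higher numbers for weaker inhibition), compound 3 gives 130 nM. Compound 2, `O=C(NO)c1cccc(/C=C/c2ccnc(-c3ccccc3O)c2)c1`, gives 390 nM in this assay, and compound 1, `O=C(NO)c1cccc(/C=C/c2ccnc(-c3cc(F)ccc3O)c2)c1`, gives 400 nM, so both stand beyond the scatter from compound 3.

Compound 4, `COc1ccccc1-c1cc(/C=C/c2ccc(C(=O)NO)cc2)ccn1`, differs from compound 3 in one place: 2-methoxyphenyl in place of 5-fluoro-2-hydroxyphenyl on an aromatic carbon. Within the data shown here, of the measured steps, only the one between compound 1 and compound 2 bears on this change, and it concerns the fluorine alone: a 1.0-fold lower number from compound 1 to compound 2 (0.01 log units; within the scatter). Taking away the fluorine is thus expected to move the number little. The second part of the change, methoxy in place of hydroxy on the same ring, has no measured counterpart among these compounds, so its effect in this assay cannot be read from the data and is the open question of the step.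

Because the known part of the change, a 1.0-fold lower number from compound 1 to compound 2 (0.01 log units; within the scatter), stayed within the scatter, compound 4 is expected to give a number near that of compound 3, with the unknown part leaving room for a modest rise: the estimate for compound 4 is 250 nM, between 90 nM and 800 nM. This corresponds to an expected step of a 1.9-fold higher number from compound 3 to compound 4 (0.28 log units; within the scatter).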

Compound 4, half-maximal inhibitory concentration: 28 nM
Beside the measured number, compound 4's estimate is 8.9-fold (0.95 log units) above it; the measured number lies below the stated range.
By their numbers in this assay, from the lowest: compound 4; then compound 3; then compounds 2 and 1 (each within the scatter of the next).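

Among these compounds, replacing 5-fluoro-2-hydroxyphenyl with 2-methoxyphenyl on an aromatic carbon next to the ring nitrogen gives a 4.6-fold lower number from compound 3 to compound 4 (0.67 log units; beyond the scatter) in this assay, so the group at this position can shift the number beyond the scatter, whereas the only earlier step there (a 1.0-fold lower number from compound 1 to compound 2 (0.01 log units; within the scatter)) stayed within it. The result also shows that a group with 1 hydrogen-bond donor is not needed at this position for a low number, since compound 4 carries 2-methoxyphenyl, with 0 hydrogen-bond donors, and still gives the lowest number of the four compounds. No measurement shown here explains why the number fell.

The step joins two changes, the loss of the fluorine and methoxy in place of hydroxy, and the compounds shown do not separate their shares on this core, where neither 2-hydroxyphenyl nor 5-fluoro-2-methoxyphenyl appears. On these data alone, it also remains open whether the gain is particular to methoxy or extends to other groups on the same ring, such as a longer ether like ethoxy or an amine.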